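Halophenyl exchange on an aromatic nitrogen at the ceiling

The source may report more compounds than this note shows. Statements on the series, on what has been measured and on what is new or still open speak of the compounds shown alone.

Three compounds sharing one core have been examined in an ADME assay on HUVEC cells (Homo sapiens) for antiproliferative activity, read by MTT assay, with a stated time of 48 h; on this read-out higher numbers stand for weaker inhibition and lower numbers for stronger inhibition. Compound 1 `N#CC1=C(N)Oc2c(c3nc4ccccc4nc3c3ccccc23)C12C(=O)N(Cc1cnnn1-c1ccc(N)cc1)c1ccccc12` sits at a limit of the assay rather than at a number: in this assay compound 1 gives > 50000 nM. Compound 2 `Cc1cccc(-n2nncc2CN2C(=O)C3(C(C#N)=C(N)Oc4c(N)cc5nc6ccccc6nc5c43)c3ccccc32)c1` likewise reaches only a limit, and in this assay compound 2 gives > 50000 nM. Compound 3 `N#CC1=C(N)Oc2c(N)cc3nc4ccccc4nc3c2C12C(=O)N(Cc1cnnn1-c1ccc(Cl)cc1)c1ccccc12` carries a 4-chlorophenyl on an aromatic nitrogen, and in this assay compound 3 gives > 50000 nM, again a limit and not a number. Compound 3 therefore stands where every measured value stands, at the limit of > 50000 nM in this assay, at which 3 of the 3 values shown sit. Going by the values given here, the one step between compounds that differ in a single place, a step that the two limits leave unreadable from compound 2 to compound 3, cannot be sized, since both of its ends are limits.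

Compound 4 `N#CC1=C(N)Oc2c(N)cc3nc4ccccc4nc3c2C12C(=O)N(Cc1cnnn1-c1ccccc1Br)c1ccccc12` differs from compound 3 by 2-bromophenyl in place of 4-chlorophenyl on an aromatic nitrogen. Among the compounds with values here, the only step that bears on this position, a step that the two limits leave unreadable from compound 2 to compound 3, gives no readable size, so the exchange of 4-chlorophenyl for 2-bromophenyl offers no measured direction. In this assay compound 4 is therefore expected to remain at the limit, with an estimated 60000 nM between 20000 nM and 200000 nM. The expected step, a step that the limit leaves unreadable from compound 3 to compound 4, is none beyond the scatter.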

Compound 4, half-maximal inhibitory concentration: 34200 nM
The estimate for compound 4 lay 1.8-fold (0.24 log units) above the measured number; low and high end bracket the measured number.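

In this assay compound 4 gives 34200 nM, so the set now holds a value at this aromatic nitrogen that is a number and not a limit. The exchange of 4-chlorophenyl for 2-bromophenyl can now be given a direction, read as an at least 1.4-fold lower number from compound 3 to compound 4 (0.16 log units; that floor lies within the scatter), and the exchange of 3-methylphenyl for 2-bromophenyl reads alike, as an at least 1.4-fold lower number from compound 2 to compound 4 (0.16 log units; that floor lies within the scatter). Both floors lie within the scatter, so neither step shows that 2-bromophenyl sets compound 4 apart from compound 2 or compound 3, and the values shown remain gathered at the ceiling of the read-out: the limit of > 50000 nM in this assay, at which 3 of the 4 values shown sit.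

Going by these compounds, how a 2-chlorophenyl or a 4-bromophenyl would read on this nitrogen stays open, and with it whether the identity of the halogen or its place on the phenyl ring matters. Also open, on these data alone, is how a group of another kind in place of the phenyl, such as a carboxylic acid, an amine or a longer alkyl chain, would read in this assay.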